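The compounds below may be only part of what the source reports. "The series", "measured", "known", "first", "only" and "open" are said of these compounds alone.

In an ADME assay on HEL cells (Homo sapiens) for cytotoxicity, with a stated time of 3 days (on this read-out lower numbers stand for higher toxicity in this test and higher numbers for lower toxicity in this test), compound 1 `CCC1(Cc2ccccc2)OS(=O)(=O)C=C1OCC#N` gives only a limit, > 400000 nM. Compound 2 `CCC1(Cc2ccccc2)OS(=O)(=O)C=C1OCc1cccc(Cl)c1` likewise gives a limit, >= 20000 nM. Compound 3 `CCC1(Cc2ccccc2)OS(=O)(=O)C=C1OCCCc1ccccc1` also returns a limit, >= 20000 nM. Compound 2 thus stands at a limit, as do the two other values shown. The steps a step that the two limits leave unreadable from compound 1 to compound 2, a step that the two limits leave unreadable from compound 1 to compound 3 and a step that the two limits leave unreadable from compound 2 to compound 3 have no readable size because the limits the limit of > 400000 nM in this assay, at which 1 of the 3 values shown sits, and the limit of >= 20000 nM in this assay, at which 2 of the 3 values shown sit, cap all three values. Compound 4 `CCC1(Cc2ccccc2)OS(=O)(=O)C=C1OC(=O)c1ccccc1` differs from compound 2 in that (benzoyl in place of 3-chlorobenzyl on an oxygen on an unsaturated carbon). The steps bearing on this change, a step that the two limits leave unreadable from compound 1 to compound 2 and a step that the two limits leave unreadable from compound 2 to compound 3, give no size, so no step beyond the scatter is expected in this assay and a further limit is likely. For compound 4 the expected step is a step that the limit leaves unreadable from compound 2 to compound 4. Compound 4 is estimated at 40000 nM, range 15000 nM to 400000 nM.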

Compound 4, minimum cytotoxic concentration: > 400000 nM
Compound 4: only a limit was reported; the forecaster's own chance of this, stated with the estimate: 80%; middle value at least 10-fold (1.00 log units) away from the limit.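

Within the data shown here, compound 1, compound 2 and compound 4 all give only limits, and no step from compound 1 or compound 2 to compound 4 can be read. The compounds shown leave open whether benzoyl in place of 3-chlorobenzyl changes the minimum cytotoxic concentration in this assay at all.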